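Swapping a Sulfur-Bearing Side Chain for Isopropyl

A few compounds are considered here, and "the series" means these few. Any claim that something is new, unique, unknown or untested is made for them only; others in the source may bear on it.

Of the compounds shown here, three have been tested so far in a functional assay on the whole organism (Tail, strain ICR) with Mus musculus as the target, in the tail flick test, with a stated time of 90 min, at a dose of 25 umol/kg by the oral route; a lower number here means a weaker effect, a higher number a stronger effect of the compound at the dose given. Compound 1 `CSCC[C@H](NC(=O)CN(c1nc(Cl)nc2[nH]cnc12)C1CC1)C(=O)OCc1ccccc1` gives 44.6%. Compound 3 `NC(=O)CC[C@H](NC(=O)CN(c1ncnc2c1ncn2C1CCCCO1)C1CC1)C(=O)OCc1ccccc1` gives 37.8%, and compound 2 `C[C@@H](O)[C@H](NC(=O)CN(c1nc(Cl)nc2[nH]cnc12)C1CC1)C(=O)O` gives 35.9%. Compound 1 has the highest number of the three, yet both other numbers lie within the usual scatter of it, so no order among them can be claimed.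

Compound 4 `CC(C)C[C@H](NC(=O)CN(c1nc(Cl)nc2[nH]cnc12)C1CC1)C(=O)OCc1ccccc1` differs from compound 1 in a single place: isopropyl in place of (methylsulfanyl)methyl on a saturated chain carbon, two bonds along the chain from an amide-type nitrogen and a carbonyl carbon. Among the compounds with values here, no measured pair shows this change, so its effect is not known from these data. Compound 4 is therefore expected to stay close to compound 1, with an estimated step of a number 2.6 percentage points lower from compound 1 to compound 4 (within the scatter) that does not go beyond the scatter in either direction. The estimate for compound 4 is 42%, within a range from 25% to 60%.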

Compound 4, a percentage reported as activity, at one dose (the size of the read-out at that dose, not a potency): 15.2%
The estimate for compound 4 lay 26.8 percentage points above the measured number; measured number below the stated range.
By their numbers in this assay, from the lowest: compound 4; then compounds 2, 3 and 1 (each within the scatter of the next).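

In this assay, within the data shown here, isopropyl in place of (methylsulfanyl)methyl on this saturated chain carbon gives a number 29.4 percentage points lower from compound 1 to compound 4 (beyond the scatter), the first single-place change that can be read here. The side chain at this position therefore matters, even though both groups have the same number of heavy atoms and neither has a ring. Nothing available explains the drop.

The compounds shown leave open whether the sulfur itself is what counts. A methoxymethyl group or an amine at this position would be needed to address that.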